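The source may report more compounds than this note shows. Statements on the series, on what has been measured and on what is new or still open speak of the compounds shown alone.

Measured in a functional assay on A-431 cells (Homo sapiens) for cytotoxicity, read by MTT assay, with a stated time of 48 h; on this read-out lower numbers stand for stronger inhibition and higher numbers for weaker inhibition:

Compound 1 `CCOC(=O)C1=C(C)NC(=S)NC1c1cccc(OCCCCOc2cccc(C3NC(=S)NC(C)=C3C(=O)OCC)c2)c1`: > 200 ug/mL (a limit, not a number)
Compound 2 `COC(=O)[C@@H]1CCCN1C(=O)C1=C(C)NC(=S)NC1c1cccc(OCCCOc2cccc(C3NC(=S)NC(C)=C3C(=O)N3CCC[C@H]3C(=O)OC)c2)c1`: 190 ug/mL
Compound 3 `COC(=O)[C@@H]1CCCN1C(=O)C1=C(C)NC(=S)NC1c1cccc(OC/C=C\COc2cccc(C3NC(=S)NC(C)=C3C(=O)N3CCC[C@H]3C(=O)OC)c2)c1`: 183 ug/mL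

Compound 3, at 183 ug/mL, holds the lowest of the two actual numbers, yet it lies within the scatter of compound 2 at 190 ug/mL. The reading for compound 1 is only a limit of the assay.

Compound 4 `COC(=O)[C@@H]1CCCN1C(=O)C1=C(C)NC(=S)NC1c1cccc(OC/C=C/COc2cccc(C3NC(=S)NC(C)=C3C(=O)N3CCC[C@H]3C(=O)OC)c2)c1` is the next one to be tested in this assay. Set against compound 3, the change is small: the two compounds have the same atoms and bonds; at least one stereo element is drawn with a configuration in one of them and without one in the other: 1 of 5 stereo elements differ; a double bond is drawn Z in compound 3 and E in compound 4. For the measured compounds named here, no measured pair shows what such a change does, so no shift beyond the scatter is expected, in either direction. The expected step of a 1.0-fold lower number from compound 3 to compound 4 (0.01 log units; within the scatter) is an estimate only. Compound 4 is estimated at 180 ug/mL, with an expected range from 120 ug/mL to 200 ug/mL.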

Compound 4, half-maximal inhibitory concentration: 96 ug/mL
Compound 4: middle estimate off by 1.9-fold (0.27 log units), on the high side, and the stated range ends above it.
By their numbers in this assay, from the lowest: compounds 4, 3 and 2 (each within the scatter of the next). At a limit, above all of these: compound 1.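

For the compounds shown here, the Z to E change of the double bond in the linking chain is the first such change that can be read, and it gives a 1.9-fold lower number from compound 3 to compound 4 (0.28 log units; within the scatter) in this assay. This pair therefore shows that, at this position, the drawn geometry of the double bond does not move the number beyond the scatter. The comparison carries one caution: the fact that one of compounds 3 and 4 is drawn with a defined configuration and the other without, at the place where they differ.

Going by these compounds, whether a longer chain in the linker would move the number beyond the scatter stays open. The same holds for a carboxylic acid in place of the methyl ester.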